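Aryl variation on the shared core: compound 3 to compound 4

The compounds below may be only part of what the source reports. "The series", "measured", "known", "first", "only" and "open" are said of these compounds alone.

Values in a functional assay on NCI-H226 cells (Homo sapiens) for inhibition, read by sulforhodamine B assay, with a stated time of 48 h, tested at 10 uM; on this read-out higher numbers stand for more inhibition at the one concentration tested (going by the name of the read-out) and lower numbers for less inhibition:
compound 1 `Brc1cn2ccnc2c(-c2ccc3ncn(C4CCCCC4)c3c2)n1` gives 22.5%
compound 2 `c1ccc(-c2cn3ccnc3c(-c3ccc4ncn(C5CCCCC5)c4c3)n2)cc1` gives 33.9%
compound 3 `COc1ccccc1-c1cn2ccnc2c(-c2ccc3ncn(C4CCCCC4)c3c2)n1` gives 25.7%

Compound 3 stands second highest of the three numbers; compound 1 is its nearest neighbour and compound 2 lies on the other side, and both gaps are within the usual scatter of this assay. Compound 4 `Fc1ccccc1-c1cn2ccnc2c(-c2ccc3ncn(C4CCCCC4)c3c2)n1` has not been measured. It differs from compound 3 by fluoro in place of methoxy on an aromatic carbon. Within the data shown here, no measured step exchanges fluoro for methoxy. The step that bears most on it is a number 8.2 percentage points lower from compound 2 to compound 3 (within the scatter), which added the methoxy group and stayed within the scatter. The steps of a number 11.4 percentage points higher from compound 1 to compound 2 (beyond the scatter) and a number 3.2 percentage points higher from compound 1 to compound 3 (within the scatter) show that both aryl groups sit at or modestly above bromo, and compound 4 keeps an aryl group. The step of a number 3.3 percentage points higher from compound 3 to compound 4 (within the scatter) is therefore expected to stay within the scatter. The estimate for compound 4 is 29%, with a range from 15% to 43%.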

Compound 4, a percentage reported as inhibition, at one concentration (the size of the read-out at that concentration, not a potency): 28.7%
The estimate for compound 4 lay 0.3 percentage points above the measured number; the range from low to high includes it.
By their numbers in this assay, from the lowest: compounds 1, 3, 4 and 2 (each within the scatter of the next, the first and the last beyond it).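

In this assay the change to 2-fluorophenyl gives a number 3 percentage points higher from compound 3 to compound 4 (within the scatter) and so does not separate fluoro from methoxy at this place, ortho to a large group. Against the unsubstituted phenyl, fluoro reads a number 5.2 percentage points lower from compound 2 to compound 4 (within the scatter) and against bromo the 2-fluorophenyl group reads a number 6.2 percentage points higher from compound 1 to compound 4 (within the scatter) so that, among the steps at this position, only a number 11.4 percentage points higher from compound 1 to compound 2 (beyond the scatter) stands clear of the scatter. Nothing available here explains these small differences.

On these data alone, the substituents on this aryl ring are limited to methoxy and fluoro, so the effect of an amine, a carboxylic acid or a longer alkyl chain at this place remains open. Because each compound is read at one concentration, the read-out also leaves their potency open.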